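From 4-fluorophenoxy to trifluoromethoxy: how much solubility remains?

This account rests on a few compounds, and the source may have more. Where it says the series, first, only, none or still open, it means among the compounds named here.

Three related compounds have been tested so far. In a physicochemical assay for solubility, using the shake flask method, in simulated intestinal fluid, measured as kinetic solubility, with a stated time of 2 h, at 25 degrees C, at pH 6.5 (a lower number here means a less soluble compound, a higher number a more soluble compound), compound 1 (`Cc1nnc(-c2nc(C)c3c(c2N)C(=O)N(Cc2ccccc2)C3=O)o1`) reads < 5000 nM as its result, and that is a limit of the assay and not a number. Compound 2 (`Cc1noc(-c2nc(C)c3c(c2N)C(=O)N(Cc2ccc(Oc4ccc(F)cc4)cc2)C3=O)n1`) gives 23800 nM in this assay and compound 3 (`Cc1noc(-c2nc(C)c3c(c2N)C(=O)N(CC2CCOCC2)C3=O)n1`) gives 5700 nM in the same test. Compound 2 therefore holds the higher of the two actual numbers, and its gap to compound 3 lies beyond the usual scatter of repeated measurements.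

Compound 4 (`Cc1noc(-c2nc(C)c3c(c2N)C(=O)N(Cc2ccc(OC(F)(F)F)cc2)C3=O)n1`) has not been measured yet. It differs from compound 2 in one place, where 4-fluorophenoxy becomes trifluoromethoxy: trifluoromethyl in place of 4-fluorophenyl on an oxygen on an aromatic ring. For the measured compounds named here, no measured pair shows this exact change, so any forecast is rough. Compound 2 with 23800 nM sits at the top of the numbers in hand and compound 3 with 5700 nM sits lower, so a fall looks more likely than a rise. The estimated step in this assay is a moderate fall, a 2.2-fold lower number from compound 2 to compound 4 (0.34 log units; beyond the scatter) in expectation. For compound 4 the expected solubility is 11000 nM with an estimated range from 5000 nM to 24000 nM as its bounds.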

Compound 4, solubility: < 5000 nM
Compound 4 ended at the assay's limit; the forecaster's own chance of this, stated with the estimate: 15%; middle value at least 2.2-fold (0.34 log units) from the limit.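

In this assay, putting trifluoromethyl in place of 4-fluorophenyl on an oxygen on an aromatic ring gives an at least 4.7-fold lower number from compound 2 to compound 4 (0.67 log units; beyond the scatter), so this position is now shown to matter for the read-out, and this single change moves it by more than the usual scatter. Before this pair, no two measured compounds differed in only one place, so the effect of any one change could not be read on its own. The printed step gives only the smallest possible size of the fall, and its true size cannot be read, because compound 4 stands at a limit of the assay and not at a number: the limit of < 5000 nM in this assay, at which 2 of the 4 values shown sit.

The change removes a six-membered aromatic ring and brings in three fluorine atoms at once, so this pair cannot say which of the two goes with the fall, and a plain methyl or an unsubstituted phenyl on the same oxygen would help to separate them. As far as these compounds go, it also stays open whether a group carrying an amine or a carboxylic acid at this position would give a number well clear of the limit.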